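Replacing the benzoyl phenyl with chloropyridinyl in the amide series

The source may hold more compounds than are shown below. What is called first, only, known or untested is meant among the compounds shown, and "the series" means these compounds.

Compound 1 `O=C(c1ccccc1)N1CCC(NS(=O)(=O)c2cc(S(=O)(=O)c3ccccc3)ccc2C(F)(F)F)CC1` is the reference of this small set. In an assay on isolated protein for displacement of a labelled ligand from secreted frizzled-related protein 1 (Homo sapiens), read by fluorescence polarization, with a stated time of 30 min (a higher number here means a weaker inhibitor, a lower number a stronger inhibitor), compound 1 gives 70 nM, the lowest number among the three measured compounds. Compound 2 `O=C(c1cccc(Cl)c1)N1CCC(NS(=O)(=O)c2cc(S(=O)(=O)c3ccccc3)ccc2C(F)(F)F)CC1` gives 300 nM and compound 3 `CN(C)c1ccc(C(=O)N2CCC(NS(=O)(=O)c3cc(S(=O)(=O)c4ccccc4)ccc3C(F)(F)F)CC2)cc1` gives 300 nM; both carry an added group on the benzoyl ring, and both are weaker than compound 1: a 4.3-fold higher number from compound 1 to compound 2 (0.63 log units; beyond the scatter) and a 4.3-fold higher number from compound 1 to compound 3 (0.63 log units; beyond the scatter). Between them there is no difference to speak of, no change at the digits printed from compound 2 to compound 3 (within the scatter).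

Compound 4 `O=C(c1ccc(Cl)nc1)N1CCC(NS(=O)(=O)c2cc(S(=O)(=O)c3ccccc3)ccc2C(F)(F)F)CC1` is not yet measured. It differs from compound 1 as follows: 6-chloropyridin-3-yl in place of phenyl on a carbonyl carbon. Among the measured compounds shown here, the new ring carries a chlorine, as compound 2 does, together with a ring nitrogen that none of the measured compounds has. For the measured compounds named here, the two steps that bear on it, a 4.3-fold higher number from compound 1 to compound 2 (0.63 log units; beyond the scatter) and a 4.3-fold higher number from compound 1 to compound 3 (0.63 log units; beyond the scatter), show that adding a group to the ring on the carbonyl carbon costs potency by a modest amount each time, and there is no example of a ring nitrogen at this position to set against that. The expectation is therefore a modest loss, in the same direction, a 3.1-fold higher number from compound 1 to compound 4 (0.50 log units; beyond the scatter). Compound 4 is estimated at 220 nM in this assay, with a range from 70 nM to 700 nM.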

Compound 4, half-maximal inhibitory concentration: 110 nM
Estimate against measurement, compound 4: 2.0-fold (0.30 log units) above; measured number inside the range.
By their numbers in this assay, from the lowest: compounds 1 and 4 (each within the scatter of the next); then compounds 2 and 3 (each within the scatter of the next).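

In this assay the change to 6-chloropyridin-3-yl gives a 1.6-fold higher number from compound 1 to compound 4 (0.20 log units; within the scatter) so a ring carrying an added group on this carbonyl carbon need not cost potency, a reading that compounds 2 and 3 alone could not offer. The chlorine by itself therefore does not set the outcome at this position: the chlorine-bearing pyridine ring gives a 2.7-fold lower number from compound 2 to compound 4 (0.44 log units; beyond the scatter) and, against the dimethylamino-bearing ring, a 2.7-fold lower number from compound 3 to compound 4 (0.44 log units; beyond the scatter) even though compound 2 also carries a chlorine. No supporting data are available to explain this difference between the rings.

Compound 4 differs from compound 2 in both the ring nitrogen and the ring position of the chlorine, so the contribution of each remains unresolved, and the pyridine ring without its chlorine, or with a methoxy group in place of the chlorine, would help to separate them. Also open, on these data alone, is how a carboxylic acid or a primary amine on this ring would behave on the same carbonyl carbon, and whether the pattern holds for a saturated ring such as cyclohexyl in place of the aromatic one.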